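Lengthening the Chain of Compound 2 by One Carbon

The compounds below may be only part of what the source reports. "The series", "measured", "known", "first", "only" and "open" are said of these compounds alone.

Values in a functional assay (spleen) for binding affinity, with Rattus norvegicus as the target, read by GTPgammaS binding; a lower number here means that less compound is needed, a higher number that more compound is needed for the effect:
Compound 1 `O=C(O)c1cc(Cc2ccccc2)n[nH]1`: 86900 nM
Compound 2 `CCCc1cc(C(=O)O)n[nH]1`: 5090 nM

Of these two compounds, compound 2 has the lower number, and the gap to compound 1 lies well beyond the scatter. Compound 3 `CCCCc1cc(C(=O)O)n[nH]1` has not yet been measured. It differs from compound 2 by methyl in place of hydrogen on a saturated chain carbon, three bonds along the chain from an aromatic carbon, which turns propyl into butyl. For the measured compounds named here, the two measured compounds offer no step at a single place to serve as a guide, so the expectation rests on the small size of this change and starts from compound 2 at 5090 nM. The expected 1.5-fold lower number from compound 2 to compound 3 (0.16 log units; within the scatter) is modest, leaning towards a lower number in this assay but not expected to go beyond the scatter. For compound 3 the estimated value is 3500 nM, with an expected range of 1200 nM to 10000 nM.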

Compound 3, half-maximal effective concentration: 2260 nM
Estimate against measurement, compound 3: 1.5-fold (0.19 log units) above; measured number inside the range.
By their numbers in this assay, from the lowest: compound 3; then compound 2; then compound 1.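

In this assay, the change now has a reading of its own: a 2.3-fold lower number from compound 2 to compound 3 (0.35 log units; beyond the scatter). For the compounds shown here, this is the first single-place step, and it shows that methyl in place of hydrogen on a saturated chain carbon, three bonds along the chain from an aromatic carbon, moves the number beyond the scatter, though only modestly, with butyl needing less compound for the effect than propyl. Nothing available explains this step.

On these data alone, one step does not make a trend, so it remains open whether a longer chain such as pentyl would lower the number further in this assay or raise it again. Also open, as far as these compounds go, is how a branched chain such as isobutyl, or a cyclopropyl group, would compare with butyl at this place.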